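A few compounds are considered here, and "the series" means these few. Any claim that something is new, unique, unknown or untested is made for them only; others in the source may bear on it.

Compound 1 `CCCCC#Cc1cn([C@H]2C[C@H](O)[C@@H](CO)O2)c(=O)[nH]c1=O` in a functional assay on L1210 cells (Mus musculus) (on this read-out higher numbers stand for weaker inhibition and lower numbers for stronger inhibition), gives 1000 ug/mL. Compound 2 `CC#CCc1cn([C@H]2C[C@H](O)[C@@H](CO)O2)c(=O)[nH]c1=O` returns in this assay only a limit of the assay, > 1000 ug/mL, so where it stands on the numbers is open. The step of a number no lower from compound 1 to compound 2 (the limit leaves the size open) therefore has no readable size. Compound 3 `CCCCCC#Cc1cn([C@H]2C[C@H](O)[C@@H](CO)O2)c(=O)[nH]c1=O` is not yet measured; its change from compound 2 is hept-1-yn-1-yl in place of but-2-yn-1-yl on an aromatic carbon. Within the data shown here, only that one measured step bears on it, and with compound 2 sitting at the limit of > 1000 ug/mL in this assay, at which 1 of the 2 values shown sits, a numerical result for compound 3 is not assured. Compound 3 is expected to give about 1000 ug/mL, in the range 500 ug/mL to 2000 ug/mL. The expected step of a number no higher from compound 2 to compound 3 (the limit leaves the size open) is accordingly none beyond the scatter.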

Compound 3, concentration for 50% inhibition: 219 ug/mL
Beside the measured number, compound 3's estimate is 4.6-fold (0.66 log units) above it; the measured number lies below the stated range.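

In this assay, this position on the aromatic carbon responds to a small extension of the chain: methyl in place of hydrogen on the saturated chain carbon gives a 4.6-fold lower number from compound 1 to compound 3 (0.66 log units; beyond the scatter), with hept-1-yn-1-yl replacing the hex-1-yn-1-yl group. Hept-1-yn-1-yl in place of but-2-yn-1-yl gives an at least 4.5-fold lower number from compound 2 to compound 3 (0.65 log units; beyond the scatter), a size that is only bounded. Compound 2 stands as a limit of the assay: the limit of > 1000 ug/mL in this assay, at which 1 of the 3 values shown sits. As far as these compounds go, whether a longer chain, such as oct-1-yn-1-yl, lowers the number further stays open, as does the outcome of an amine or a carboxylic acid at the chain end.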